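The compounds below may be only part of what the source reports. "The series", "measured", "known", "first", "only" and "open" are said of these compounds alone.

Compound 1 `Nc1cc(N)c2nc(-c3ccccc3)c(NCc3ccc(Cl)c(Cl)c3)nc2c1`; in a functional assay on 786-0 cells (Homo sapiens) for inhibition, read by sulforhodamine B assay, with a stated time of 48 h (a higher number here means a weaker inhibitor of growth, a lower number a stronger inhibitor of growth), compound 1 gives 13200 nM.
Compound 2 `COc1ccc(CNc2nc3cc(N)cc(N)c3nc2-c2ccccc2)cc1OC`; in this assay compound 2 gives 15500 nM.

Compound 2 carries the higher of these two numbers, but its gap to compound 1 lies within the scatter. Compound 3 `COc1cc(CNc2nc3cc(N)cc(N)c3nc2-c2ccccc2)cc(OC)c1OC` differs from compound 2 by methoxy in place of hydrogen on an aromatic carbon. Going by the values given here, the one measured step, a 1.2-fold higher number from compound 1 to compound 2 (0.07 log units; within the scatter), also altered this same ring and stayed within the scatter, so no shift beyond the scatter is expected in this assay. Compound 3 is estimated at 15000 nM, with a range from 6000 nM to 40000 nM. The expected step is a 1.0-fold lower number from compound 2 to compound 3 (0.01 log units; within the scatter).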

Compound 3, concentration for 50% growth inhibition: 15500 nM
Compound 3: middle estimate off by 1.0-fold (0.01 log units), on the low side, within the range that was stated.
By their numbers in this assay, from the lowest: compounds 1, 2 and 3 (each within the scatter of the next).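

In this assay methoxy in place of hydrogen, on the aromatic carbon ortho to a methoxy group and meta to a large group, gives no change at the digits printed from compound 2 to compound 3 (within the scatter) and so this carbon takes an added methoxy without a shift beyond the scatter. The earlier pair swapped groups on this ring and left this carbon unchanged, so it could not show this. Nothing measured here explains the result.

As far as these compounds go, whether an amine or a carboxylic acid on this same carbon would also leave the number within the scatter stays open.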